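This account rests on a few compounds, and the source may have more. Where it says the series, first, only, none or still open, it means among the compounds named here.

Measured so far in a functional assay (strain AB) with Danio rerio as the target, read by microscopy, with a stated time of 1 h; on this read-out higher numbers stand for an effect only at larger amounts of compound and lower numbers for an effect already at smaller amounts:
- compound 1 `CC(C)(C)C[N+]1(C)CCc2c(sc(NC(=O)Nc3ccc(Cl)cc3)c2C(N)=O)C1` — 290 nM
- compound 2 `NC(=O)c1c(NC(=O)Nc2ccc(Cl)cc2)sc2c1CCN(CC1CCCC1)C2` — 1830 nM
- compound 3 `CCN1CCc2c(sc(NC(=O)Nc3ccc(Cl)cc3Cl)c2C(N)=O)C1` — 11500 nM

Compound 1 gives the lowest number of the three, and its gaps to compound 2 and to compound 3 both lie beyond the scatter, so in this assay compound 1 is the most potent compound measured here. Compound 4 `CC(C)(C)OC(=O)CCCCC[N+]1(C)CCc2c(sc(NC(=O)Nc3ccc(Cl)cc3)c2C(N)=O)C1` has not yet been measured. It differs from compound 1 as follows: 4-(tert-butoxycarbonyl)butyl in place of tert-butyl on a saturated chain carbon bound to an amine nitrogen in a ring. Going by the values given here, no pair among the measured compounds differs in this one place alone, so no step for a change of this kind is known. In this assay the step of a 2.8-fold higher number from compound 1 to compound 4 (0.44 log units; beyond the scatter) is expected to be a modest rise, with a wide range allowed. For compound 4 the estimate is 800 nM, between 200 nM and 3500 nM.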

Compound 4, half-maximal effective concentration: 110 nM
Compound 4: middle estimate off by 7.3-fold (0.86 log units), on the high side, outside the stated range (below it).
By their numbers in this assay, from the lowest: compound 4; then compound 1; then compound 2; then compound 3.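

In this assay, 4-(tert-butoxycarbonyl)butyl in place of tert-butyl on a saturated chain carbon bound to an amine nitrogen in a ring gives a 2.6-fold lower number from compound 1 to compound 4 (0.42 log units; beyond the scatter). This place therefore accepts a much larger group, 11 heavy atoms against 4 and carrying 2 hydrogen-bond acceptors, with no loss in this assay. Nothing available explains the lower number.

A single step cannot separate the contribution of chain length from that of the ester. A plain hexyl chain, a free carboxylic acid or a primary amide at the chain end would address this.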